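Cytotoxicity notes on compounds 1 to 3

A few compounds are considered here, and "the series" means these few. Any claim that something is new, unique, unknown or untested is made for them only; others in the source may bear on it.

Measured so far:
compound 1 `CCOc1cccc(-c2ccc(C(=O)N(Cc3cccc(OCCCCCC(=O)O)c3)C(C)C)cc2)c1` — > 20800 nM
compound 2 `CCOC(=O)CCCCCOc1cccc(CN(C(=O)c2ccc(-c3cccnc3)cc2)C(C)C)c1` — > 26000 nM

In an ADME assay on HEK293 cells (Homo sapiens) for cytotoxicity, read by CellTiter-Glo and resazurin assay, with a stated time of 72 h (on this read-out higher numbers stand for an effect only at larger amounts of compound and lower numbers for an effect already at smaller amounts), compound 1 gives > 20800 nM, which is a limit of the assay rather than a number. Compound 2 gives > 26000 nM in this assay, again a limit. Compound 2 therefore stands at the limit of > 26000 nM in this assay, at which 1 of the 2 values shown sits, with no number to set it apart from compound 1.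

Compound 3 `CCOC(=O)CCCCCOc1cccc(CN(C(=O)c2ccc(-c3cccc(C(F)(F)F)c3)cc2)C(C)C)c1` differs from compound 2 in one place:
3-(trifluoromethyl)phenyl in place of pyridin-3-yl on an aromatic carbon

For the measured compounds named here, no step between measured compounds is available, so the change is untested here. The step of an at least 1.3-fold lower number from compound 2 to compound 3 (0.11 log units; that floor lies within the scatter) is expected to lie within the scatter, with no clear direction. Compound 3 is estimated at 20000 nM, in the range 7000 nM to 40000 nM, and a further limit is expected to be the most likely outcome.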

Compound 3, half-maximal effective concentration: > 26000 nM
Compound 3: a limit, no number; the forecaster's own chance of this, stated with the estimate: 65%; at least 1.3-fold (0.11 log units) between middle value and limit.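

In this assay, compound 2 and compound 3 both give limits rather than numbers, so no step between them can be read: the limit of > 26000 nM in this assay, at which 2 of the 3 values shown sit.

From the compounds shown here alone, whether 3-(trifluoromethyl)phenyl in place of pyridin-3-yl moves the half-maximal effective concentration at all remains open.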